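Series notes: alpha-methyl on the benzylamine of compound 2

A few compounds are considered here, and "the series" means these few. Any claim that something is new, unique, unknown or untested is made for them only; others in the source may bear on it.

For the measured compounds named here, compound 2 `COc1cc(C(=O)N2CCC(O)C(C)C2)cc2nc(NCc3cccc(Cl)c3)oc12` gives 25 nM in an assay on isolated protein for inhibition of thyroid hormone receptor beta (Homo sapiens), read by fluorescence, with a stated time of 30 min (on this read-out lower numbers stand for stronger inhibition and higher numbers for weaker inhibition), and holds the lowest of the three numbers measured so far. Compound 1 `COc1cc(C(=O)N2CCCC2(C)C)cc2nc(NCc3cccc(Cl)c3)oc12` gives 47 nM in this assay, and the step of a 1.9-fold lower number from compound 1 to compound 2 (0.27 log units; within the scatter) stays within the scatter. Compound 3 `COc1cc(C(=O)N2CC[C@H](O)[C@@H](C)C2)cc2nc(NCc3cccc(Cl)c3)oc12` gives 120 nM in this assay; the step of a 4.8-fold higher number from compound 2 to compound 3 (0.68 log units; beyond the scatter) lies beyond the scatter, and the two compounds differ only in that (the fact that one of compounds 2 and 3 is drawn with a defined configuration and the other without, at the place where they differ). The step of a 2.6-fold higher number from compound 1 to compound 3 (0.41 log units; beyond the scatter) is of a similar modest size.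

Compound 4 `COc1cc(C(=O)N2CCC(O)C(C)C2)cc2nc(N[C@@H](C)c3cccc(Cl)c3)oc12` differs from compound 2 by methyl in place of hydrogen on a saturated chain carbon bound to an aromatic carbon and a nitrogen on an aromatic ring, with the new centre drawn in one configuration. Going by the values given here, none of the measured steps touches this part of the molecule: all three concern the amide ring or its drawn configuration, so they give no direct guide to the size or direction of the change from compound 2 to compound 4. With nothing measured on this side, the expectation is a step of no more than the scatter, a 1.2-fold higher number from compound 2 to compound 4 (0.08 log units; within the scatter), in either direction. Compound 4 is therefore estimated to give 30 nM in this assay, with a range from 10 nM to 100 nM.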

Compound 4, half-maximal inhibitory concentration: 5100 nM
Estimate against measurement, compound 4: 170-fold (2.23 log units) below, and the stated range ends below it.
By their numbers in this assay, from the lowest: compounds 2 and 1 (each within the scatter of the next); then compound 3; then compound 4.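

The saturated chain carbon bound to an aromatic carbon and a nitrogen on an aromatic ring is far more sensitive to change than anything seen so far in the amide ring: in this assay, methyl in place of hydrogen gives a 200-fold higher number from compound 2 to compound 4 (2.31 log units; beyond the scatter), well beyond the largest earlier step, a 4.8-fold higher number from compound 2 to compound 3 (0.68 log units; beyond the scatter). The change adds a single carbon, with no ring, no hydrogen-bond donor or acceptor and no net charge, so even this smallest of substitutions at this carbon is not tolerated in the configuration drawn for compound 4, and the result speaks for that configuration alone. Nothing measured on these compounds bears on the reason for this large rise in the number.

The compounds shown leave open how the opposite configuration at this carbon reads, and whether an ethyl or a hydroxymethyl group there would fall in line with methyl. Also open, from the compounds shown here alone, is whether the same methyl gives a step of similar size on the 2,2-dimethylpyrrolidin-1-yl amide of compound 1 or on the defined amide ring of compound 3.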